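What one methyl group may do to compound 1

The compounds below may be only part of what the source reports. "The series", "measured", "known", "first", "only" and "open" are said of these compounds alone.

Values so far in a functional assay, read by spectrophotometry, with a stated time of 20 min (a higher number here means a weaker inhibitor, a lower number a stronger inhibitor), are these.
- Compound 1 `Cc1c(-c2ccccc2)oc2ccccc2c1=O` gives 106 ug/mL as its value
- Compound 2 `Cc1c(-c2ccccc2F)oc2ccccc2c1=O` gives 208 ug/mL as its value

Among the compounds with values here, compound 1 serves as the starting point, and only one other measured compound is available for comparison. The step between them is a 2.0-fold higher number from compound 1 to compound 2 (0.29 log units; within the scatter) and comes from fluoro in place of hydrogen on an aromatic carbon. The two numbers therefore cannot be told apart in this kind of measurement.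

Compound 3 (`Cc1cccc(-c2oc3ccccc3c(=O)c2C)c1`) has not yet been measured. It differs from compound 1 by methyl in place of hydrogen on an aromatic carbon, meta to a large group (methyl in place of hydrogen on an aromatic carbon).

Within the data shown here, the fluoro step is the only measured evidence that bears on this change. It is a single example with a different group, so it is a loose guide. Since that step stayed within the scatter, no clear shift in either direction is expected in this assay for the methyl group. The expected change is a 1.2-fold higher number from compound 1 to compound 3 (0.07 log units; within the scatter) and this estimate carries real uncertainty. For compound 3 the estimated value is 125 ug/mL with an expected range from 60 ug/mL to 250 ug/mL in repeated measurements.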

Compound 3, half-maximal inhibitory concentration: 250 ug/mL
Compound 3: middle estimate off by 2.0-fold (0.30 log units), on the low side; measured number inside the range.
By their numbers in this assay, from the lowest: compounds 1, 2 and 3 (each within the scatter of the next, the first and the last beyond it).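

In this assay methyl in place of hydrogen on an aromatic carbon, meta to a large group, gives a 2.4-fold higher number from compound 1 to compound 3 (0.37 log units; beyond the scatter) and so moves toward a weaker inhibitor. Within the data shown here, this is the first change to compound 1 in this set that lies beyond the scatter, though only modestly, whereas the fluoro change gives a 2.0-fold higher number from compound 1 to compound 2 (0.29 log units; within the scatter) and cannot be told apart from no change. Nothing available explains why the added methyl has this effect, so the result stands as an observation without a reason.

The compounds shown leave open whether this shift belongs to the methyl group itself or to any group placed on this carbon, a question that a chlorine atom, a hydroxyl or a methoxy group at the same place could help to answer. They also leave open whether a longer chain, such as ethyl or propyl, would move the number further in the same direction, and whether the same methyl group would give a similar shift on another carbon of this ring.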